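The source may report more compounds than this note shows. Statements on the series, on what has been measured and on what is new or still open speak of the compounds shown alone.

Measured so far:
compound 1, `CC(C(=O)NCc1ccc(C(F)(F)F)nc1NCc1cccnc1)c1ccc(NS(C)(=O)=O)c(F)c1`: "not active" (no number reported) in a functional assay on CHO-K1 cells for antagonist activity at transient receptor potential cation channel subfamily V member 1 (Homo sapiens), read by FLIPR; on this read-out higher numbers stand for weaker inhibition and lower numbers for stronger inhibition
compound 2, `CC(C(=O)NCc1ccc(C(F)(F)F)nc1N1CCCC1)c1ccc(NS(C)(=O)=O)c(F)c1`: 0.6 nM

Within the data shown here, compound 2 holds the only number reported; compound 1 was recorded as not active, with no number given, so the two cannot be set against each other as a step. Compound 3, `COC1CCN(c2nc(C(F)(F)F)ccc2CNC(=O)C(C)c2ccc(NS(C)(=O)=O)c(F)c2)CC1`, takes the change (4-methoxypiperidin-1-yl in place of pyrrolidin-1-yl on an aromatic carbon). Among the measured compounds shown here, the difference brings a larger ring carrying an added acceptor, and no step between measured compounds shows how such a change plays out here. A modest loss, close to the edge of the usual scatter, is expected, so that the estimated step is a 2.5-fold higher number from compound 2 to compound 3 (0.40 log units; beyond the scatter). Compound 3 is estimated at 1.5 nM, within 0.4 nM to 6 nM.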

Compound 3, inhibition constant: 2.4 nM
Estimate against measurement, compound 3: 1.6-fold (0.20 log units) below, and the stated range covers the measured number.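

In this assay, among these compounds, putting 4-methoxypiperidin-1-yl in place of pyrrolidin-1-yl gives a 4.0-fold higher number from compound 2 to compound 3 (0.60 log units; beyond the scatter), the first step that can be read at this position. The position, on an aromatic carbon next to the ring nitrogen, therefore takes the larger six-membered ring at a modest cost, and compound 3 still reaches 2.4 nM. No measurement shown here explains this loss.

Whether the ring size or the methoxy group accounts for the step stays open. A plain piperidin-1-yl at this position would separate the two.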